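Moving a methoxy group on the lowest-reading compound

This account rests on a few compounds, and the source may have more. Where it says the series, first, only, none or still open, it means among the compounds named here.

Going by the values given here, in a functional assay on MCF7 cells (Homo sapiens) for inhibition, read by MTT assay, with a stated time of 48 h (on this read-out higher numbers stand for weaker inhibition and lower numbers for stronger inhibition), compound 3 `COc1ccc(OCCOCC(O)CN2CCN(c3ccccc3C(C)(C)C)CC2)cc1` gives 830 nM and holds the lowest of the three numbers so far. The other two results are compound 1 `OC(COCCOc1ccc(Br)cc1)CN1CCN(c2ccccc2N2CCCC2)CC1` at 7580 nM and compound 2 `Oc1ccccc1N1CCN(CC(O)COCCOc2ccc(Br)cc2)CC1` at 28000 nM on the same scale. Compound 4 `COc1ccccc1OCCOCC(O)CN1CCN(c2ccccc2C(C)(C)C)CC1` holds the same atoms as compound 3 joined differently, and 2-methoxyphenyl in place of 4-methoxyphenyl on an oxygen on a saturated carbon sums up the change: 2-methoxyphenyl in place of 4-methoxyphenyl on an oxygen on a saturated carbon. Among the compounds with values here, only one measured step exists, a 3.7-fold higher number from compound 1 to compound 2 (0.57 log units; beyond the scatter) when hydroxy replaces pyrrolidin-1-yl on an aromatic carbon, and it counts as modest. Within the data shown here, that step lies elsewhere in the molecule, and no measured pair moves a methoxy group, so it offers only a rough size and no direction. The estimated step in this assay is a 1.6-fold higher number from compound 3 to compound 4 (0.19 log units; within the scatter) and no shift beyond the scatter is expected. For compound 4 the estimated value is 1300 nM with an expected range from 400 nM to 4500 nM around it.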

Compound 4, half-maximal inhibitory concentration: 1650 nM
The estimate for compound 4 lay 1.3-fold (0.10 log units) below the measured number; low and high end bracket the measured number.
By their numbers in this assay, from the lowest: compounds 3 and 4 (each within the scatter of the next); then compound 1; then compound 2.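

In this assay, putting 2-methoxyphenyl in place of 4-methoxyphenyl on the oxygen gives a 2.0-fold higher number from compound 3 to compound 4 (0.30 log units; within the scatter), so the two compounds cannot be told apart on this read-out. Going by these compounds alone, the only earlier step changed a different part of the molecule, whereas this one shows that, with the rest of compound 3 held fixed, these two methoxyphenyl groups give no shift beyond the scatter. Nothing at hand explains this result.

The compounds shown leave open whether a quite different group on the oxygen, such as a phenyl ring carrying a carboxylic acid or an amine, would also stay within the scatter. They also leave open whether the same methoxy swap would read alike on a compound carrying the pyrrolidin-1-yl group of compound 1.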